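This account rests on a few compounds, and the source may have more. Where it says the series, first, only, none or still open, it means among the compounds named here.

Working notes on the series. Compound 3 `CCOC(=O)c1cnn(-c2nc(-c3cccs3)c(C#N)c(=O)n2C)c1N` and compound 1 `CCOC(=O)c1cnn(-c2nc(-c3ccco3)c(C#N)c(=O)n2C)c1N` share one core; compound 2 `Cn1c(NN)nc(-c2cccs2)c(C#N)c1=O` and the unmeasured compound 4 `Cn1c(NN)nc(-c2ccco2)c(C#N)c1=O` share another, and the difference between the two cores is not broken down here. In a functional assay, with a stated time of 20 min (a lower number here means a stronger inhibitor, a higher number a weaker inhibitor), compound 3 gives 79 ug/mL, compound 1 gives 91 ug/mL, and compound 2 gives 61 ug/mL; all three lie within the usual scatter of one another, so no order among them is claimed.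

For the measured compounds named here, the only counted change in the measured set, (furan-2-yl in place of thiophen-2-yl on an aromatic carbon), produced a 1.2-fold higher number from compound 3 to compound 1 (0.06 log units; within the scatter). The move from compound 2 to compound 4 is a change of the same kind, (furan-2-yl in place of thiophen-2-yl on an aromatic carbon), though not the same: its surroundings differ in one respect, the position being meta to an aminoamino group (2 heavy atoms) in compound 2 where it is meta to a large group in compound 3. Because a 1.2-fold higher number from compound 3 to compound 1 (0.06 log units; within the scatter) stayed within the scatter, a small step is expected here too. For compound 4 in this assay the expected step is a 1.1-fold higher number from compound 2 to compound 4 (0.06 log units; within the scatter). Compound 4 in this assay is accordingly estimated at 70 ug/mL, with a range from 35 ug/mL to 140 ug/mL. This rests on a single measured precedent, so the expectation is held loosely.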

Compound 4, half-maximal inhibitory concentration: 64 ug/mL
Estimate against measurement, compound 4: 1.1-fold (0.04 log units) above, and the stated range covers the measured number.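

In this assay, furan-2-yl in place of thiophen-2-yl on the core of compound 2 gives a step of the same small size as on the other core (a 1.0-fold higher number from compound 2 to compound 4 (0.02 log units; within the scatter)), and the two steps do not differ: the same change on two cores in this assay, a 1.2-fold higher number (0.06 log units; within the scatter) from compound 3 to compound 1 and a 1.0-fold higher number (0.02 log units; within the scatter) from compound 2 to compound 4, 1.1-fold (0.04 log units) apart, within the scatter of two such steps. Within these two pairs, the change therefore carries from one core to the other as a step that stays within the scatter, so thiophen-2-yl and furan-2-yl cannot be told apart on either core in this assay. This does not show that a step of real size would carry over in the same way, since neither step stands clear of the scatter, and two pairs give no rule for other cores or say anything about how the two cores compare with each other.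

The compounds shown leave open whether a group other than these two five-membered aromatic rings, such as phenyl or a simple amine, on the same aromatic carbon would move the number beyond the scatter. They also leave open what a carboxylic acid in place of the cyano group, or a longer chain in place of the methyl group, would do on either core.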